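The source may hold more compounds than are shown below. What is called first, only, known or untested is meant among the compounds shown, and "the series" means these compounds.

Of the compounds shown here, three built on one shared core have been measured in an ADME assay on microsomes from liver (Mus musculus) for metabolic stability, with a stated time of 30 min, tested at 1 uM; a higher number here means that more of the compound is left, a lower number that less of the compound is left. Compound 2 `CCC1C(=O)N(C)c2cnc(-n3ccnc3-c3ccc(F)cc3)nc2N1c1ccc(F)cc1` gives 41%. Compound 1 `CC[C@@H]1C(=O)N(C)c2cnc(-n3ccnc3-c3ccc(F)cc3)nc2N1CCC(F)(F)F` gives 32%. Compound 3 `CCC1C(=O)N(C)c2cnc(-n3ccnc3-c3ccccc3)nc2N1c1ccccc1` gives 28%. Compound 2 lies within the scatter of compound 1 and beyond the scatter above compound 3.

Compound 4 `CCC1C(=O)N(C)c2cnc(-n3ccnc3-c3ccc(F)cc3)nc2N1c1ccc(C#N)cc1` departs from compound 2 in a single place: cyano in place of fluoro on an aromatic carbon. The change turns the 4-fluorophenyl into a 4-cyanophenyl. Among the measured compounds shown here, no measured pair isolates a change at this place, so the data give no direct size for such a step. For the measured compounds named here, the expectation therefore starts from compound 2 at 41% and takes the narrow band of the three measured numbers as its only guide. A slight fall is the likelier direction, since compound 2 sits at the top of that band, but nothing beyond the scatter is expected. The estimate is a number 5 percentage points lower from compound 2 to compound 4 (within the scatter). For compound 4 the expected value is 36%, with an estimated range from 22% to 50%.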

Compound 4, percent of the compound remaining: 49%
Estimate against measurement, compound 4: 13 percentage points below; measured number inside the range.
By their numbers in this assay, from the lowest: compounds 3, 1, 2 and 4 (each within the scatter of the next, the first and the last beyond it).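

In this assay, among the compounds shown here, cyano in place of fluoro on an aromatic carbon, para to a large group, gives a number 8 percentage points higher from compound 2 to compound 4 (within the scatter), the first measured step at this place. The 4-fluorophenyl can therefore become a 4-cyanophenyl, a group that brings a triple bond and a hydrogen-bond acceptor, without a shift beyond the usual scatter. No measurement at hand bears on what lies behind this step.

On these data alone, whether an amine, a carboxylic acid or a longer chain at this same place would also stay within the scatter remains open, since a single step cannot show how far this tolerance extends. As far as these compounds go, it also remains open whether cyano in place of fluoro on the other 4-fluorophenyl of compound 2 would give a similar result.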